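Beta-substituted acrylamide analogues on the indolyl-pyrimidine series

A few compounds are considered here, and "the series" means these few. Any claim that something is new, unique, unknown or untested is made for them only; others in the source may bear on it.

Measured so far:
compound 1 `COc1cc(N(C)CCN(C)C)c(NC(=O)C=C(C)C)cc1Nc1nccc(-c2cn(C)c3ccccc23)n1`: 5660 nM
compound 2 `C=CC(=O)Nc1cc(Nc2nccc(-c3cn(C)c4ccc(F)cc34)n2)c(OC)cc1N(C)CCN(C)C`: 429 nM

In a functional assay on HepG2 cells (Homo sapiens) for antiproliferative activity, read by MTT assay, with a stated time of 72 h (on this read-out higher numbers stand for weaker inhibition and lower numbers for stronger inhibition), compound 2 gives 429 nM, the lowest of the two numbers; compound 1, the nearest, gives 5660 nM, and the gap between the two lies well beyond the scatter. Within the data shown here, no pair of measured compounds differs in a single place, so no step can be separated from the others; compound 1 differs from compound 2 both in the group on the carbonyl carbon and on the fused ring, and the two values show only that compound 2 is the stronger of the two.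

Compound 3 `CCC/C=C\C(=O)Nc1cc(Nc2nccc(-c3cn(C)c4ccc(F)cc34)n2)c(OC)cc1N(C)CCN(C)C` has not been measured. It differs from compound 2 by pent-1-en-1-yl in place of vinyl on a carbonyl carbon; the amide, the basic side chain and the fluorinated core are unchanged.

Among the measured compounds shown here, with no single-point step to lean on, the expectation rests on the direction the two measured values point: a lengthened chain on the carbonyl carbon is expected to raise the number in this assay, by a step clearly beyond the scatter, a 4.2-fold higher number from compound 2 to compound 3 (0.62 log units; beyond the scatter). Compound 3 is therefore estimated at 1800 nM, with a range of 500 nM to 6500 nM.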

Compound 3, half-maximal inhibitory concentration: 3400 nM
Estimate against measurement, compound 3: 1.9-fold (0.28 log units) below; the range from low to high includes it.
By their numbers in this assay, from the lowest: compound 2; then compounds 3 and 1 (each within the scatter of the next).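

In this assay, among these compounds, the change from vinyl to pent-1-en-1-yl on a carbonyl carbon gives a 7.9-fold higher number from compound 2 to compound 3 (0.90 log units; beyond the scatter), the first step that can be read at a single place. The amide, the side chain and the fluorinated core stay the same along this step, so the group on the carbonyl carbon alone is enough to weaken inhibition by more than the scatter. Compound 1 and compound 2 could not offer that separation. They differ in two places. Nothing at hand bears on why the number rises with this change.

A single enlarged group cannot show whether the number climbs steadily with chain length or whether a shorter chain such as prop-1-en-1-yl already brings the full rise, and a chain bearing an amine such as dimethylamino is a separate question again. As far as these compounds go, whether the same step holds on the core of compound 1, which lacks the fluorine, also remains open.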